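Notes on an anilino variant of compound 1

This account rests on a few compounds, and the source may have more. Where it says the series, first, only, none or still open, it means among the compounds named here.

compound 1 `Cc1c(C)c2c(c(C)c1N)CC(C)(C)O2` — 7.8 mg/kg
compound 2 `Cc1c(C)c2c(c(N)c1N)CC(C)(C)O2` — > 50 mg/kg (a limit)
compound 3 `Cc1c(N)c(C)c2c(c1CN(C)C)OC(C)(C)C2` — > 50 mg/kg (a limit)

Within the data shown here, in a functional assay on the whole organism with Mus musculus as the target (on this read-out lower numbers stand for an effect already at smaller amounts and higher numbers for an effect only at larger amounts of compound), compound 1 gives 7.8 mg/kg, the only plain number in the set. For compound 2 the read-out is a limit, > 50 mg/kg. For compound 3 the read-out is likewise a limit, > 50 mg/kg. Both measured steps away from compound 1 went the same way: an at least 6.4-fold higher number from compound 1 to compound 2 (0.80 log units; beyond the scatter) and an at least 6.4-fold higher number from compound 1 to compound 3 (0.80 log units; beyond the scatter), each ending at the limit of > 50 mg/kg in this assay, at which 2 of the 3 values shown sit.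

Compound 4 `Cc1c(C)c2c(c(C)c1N)CC(C)(CNc1ccccc1)O2` is not yet measured in this assay. It differs from compound 1 by anilino in place of hydrogen on a saturated chain carbon bound to a saturated ring carbon. Among the measured compounds shown here, no measured step touches this place, and neither measured step adds an anilino group. The two known changes, amino in place of methyl on an aromatic carbon and dimethylamino in place of hydrogen on a saturated chain carbon bound to an aromatic carbon, both carried the number past the limit. Compound 4 is therefore expected to give a higher number than compound 1, by a step of about a 3.2-fold higher number from compound 1 to compound 4 (0.51 log units; beyond the scatter). The estimate for compound 4 is 25 mg/kg, with a range from 8 mg/kg to 80 mg/kg, and a real chance that this assay again reports only a limit.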

Compound 4, dose for 50% inhibition: 15.7 mg/kg
For compound 4 the middle estimate is 1.6-fold (0.20 log units) above the measured one; the measured number falls inside the stated range.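

Among these compounds, this position tolerates far more than the earlier compounds could show. In this assay, anilino in place of hydrogen on a saturated chain carbon bound to a saturated ring carbon gives a 2.0-fold higher number from compound 1 to compound 4 (0.30 log units; within the scatter), so a group carrying a six-membered aromatic ring fits here without a reading beyond the scatter. Of the three changes made to compound 1, this is the only one that yields a plain number, while compound 2 and compound 3 end at a limit: the limit of > 50 mg/kg in this assay, at which 2 of the 4 values shown sit.

On these data alone, it remains open whether the aromatic ring or the chain nitrogen matters here, and a dimethylamino or benzylamino group on this same carbon would separate the two. A chloroanilino group at this place would show whether substitution on the ring is tolerated as well.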